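The source may hold more compounds than are shown below. What is called first, only, known or untested is meant among the compounds shown, and "the series" means these compounds.

In an ADME assay on BaF3 cells (Mus musculus) for antiproliferative activity, read by CellTiter-Glo and CCK-8 assay, with a stated time of 72 h (a higher number here means a weaker inhibitor of growth, a lower number a stronger inhibitor of growth), compound 2 `Cc1ccc(Nc2ncc3c(n2)N(C)C(=O)N(c2cc(NC(=O)c4cccc(C(F)(F)F)c4)ccc2C)C3)cc1N` gives 440 nM. Compound 1 `CNc1cc(Nc2ncc3c(n2)N(C)C(=O)N(c2cc(NC(=O)c4cccc(C(F)(F)F)c4)ccc2C)C3)ccc1C` is its counterpart carrying (methyl in place of hydrogen on a nitrogen on an aromatic ring). In this assay compound 1 returns only a limit of the assay, > 10000 nM, and not a number. The step of an at least 22-fold higher number from compound 2 to compound 1 (1.35 log units; beyond the scatter) thus marks a large loss of growth inhibition within the shared core of compound 1 and compound 2.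

Compound 3 `CNc1nc(Nc2ccc(C)c([N+](=O)[O-])c2)ncc1C(=O)Nc1cc(NC(=O)c2cccc(C(F)(F)F)c2)ccc1C` rests on another core, and the difference between the two cores is not broken down here. In this assay compound 3 likewise sits at a limit of the assay, > 10000 nM.

Compound 4 `Cc1ccc(NC(=O)c2cccc(C(F)(F)F)c2)cc1NC(=O)c1cnc(Nc2ccc(C)c([N+](=O)[O-])c2)nc1N(C)C` has not yet been measured; it differs from compound 3 by methyl in place of hydrogen on a nitrogen on an aromatic ring. Within the data shown here, this is the same kind of change as the one from compound 2 to compound 1, but not the same: in compound 2 the other neighbour of the nitrogen is an aromatic carbon, whereas in compound 3 the other neighbours of that nitrogen are an aromatic carbon and a saturated chain carbon. The measured step of this kind, from compound 2 to compound 1, lay beyond the scatter and weakened inhibition.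

The expected step here is a step that the limit leaves unreadable from compound 3 to compound 4, because compound 3 already sits at the limit of > 10000 nM in this assay, at which 2 of the 3 values shown sit, and no movement toward weaker inhibition can register as a number. Compound 4 is expected to give 20000 nM in this assay, with an estimated range from 8000 nM to 60000 nM and the most likely outcome again a limit rather than a number.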

Compound 4, concentration for 50% growth inhibition: > 10000 nM
Compound 4: no number, only a limit; the forecaster's own chance of this, stated with the estimate: 85%; the middle value lies beyond the limit too.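

In this assay compound 4 gives > 10000 nM and thus a limit of the assay, not a number. Compound 3 also stands at a limit, so the step between compound 3 and compound 4, methylamino to dimethylamino, cannot be read: the limit of > 10000 nM in this assay, at which 3 of the 4 values shown sit. The compounds shown leave open whether this change weakens growth inhibition on this core as the methyl did within the shared core of compound 1 and compound 2.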